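Lipophilicity notes: compound 1 to compound 3

The source may report more compounds than this note shows. Statements on the series, on what has been measured and on what is new or still open speak of the compounds shown alone.

For the measured compounds named here, compound 1, `CN1CCC(c2ccc(OCc3ccccc3)c(C(=O)Nc3ccnnc3)c2)CC1`, gives the lower of the two numbers so far in a physicochemical assay for lipophilicity, at pH 7.4 (a higher number here means a more lipophilic compound, a lower number a more polar compound), with a value of 2.3. The nearest measured neighbour is compound 2, `N#Cc1cccc(NC(=O)c2cc(C(F)(F)F)ccc2OCc2ccc(F)cc2)c1`, which in this assay gives 7.5, a gap beyond the scatter; the two structures differ in several places, so only the two values themselves are compared here.

Compound 3, `O=C(Nc1ccnnc1)c1cc(N2CCC(CO)CC2)ccc1OCc1ccccc1`, awaits measurement in this assay. It differs from compound 1 by 4-(hydroxymethyl)piperidin-1-yl in place of 1-methylpiperidin-4-yl on an aromatic carbon.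

Going by the values given here, no measured step covers this change, so the expectation is a moderate rise from compound 1 to compound 3 of a number 0.80 log units higher from compound 1 to compound 3 (beyond the scatter), and compound 3 is estimated at 3.1 within the range 2.3 to 3.9.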

Compound 3, distribution coefficient: 3.5
Compound 3: the middle estimate sits 0.40 log units below what was measured; low and high end bracket the measured number.
By their numbers in this assay, from the lowest: compound 1; then compound 3; then compound 2.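

In this assay, for the compounds shown here, this aromatic carbon para to the benzyloxy group responds strongly: 4-(hydroxymethyl)piperidin-1-yl in place of 1-methylpiperidin-4-yl gives a number 1.20 log units higher from compound 1 to compound 3 (beyond the scatter), the first single-place step. The number rises although the entering group carries a hydrogen-bond donor and the leaving group none. Nothing available accounts for the direction of this step.

The change alters both the ring attachment and the ring substituent, and the compounds shown do not separate the two. On these data alone, how an unsubstituted piperidin-1-yl or a carboxylic acid would read at this position remains open.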